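The compounds below may be only part of what the source reports. "The series", "measured", "known", "first", "only" and "open" are said of these compounds alone.

Going by the values given here, in a functional assay for antagonist activity at C-X-C chemokine receptor type 3 (Homo sapiens) (a lower number here means a stronger inhibitor, a higher number a weaker inhibitor), compound 2 `CC(=O)Nc1cnc(N2CCN(C3CCN(Cc4ccc(Cl)cc4)CC3)[C@@H](C)C2)c(Cl)c1` gives 8 nM, the lowest of the two numbers measured so far; compound 1 `CC(=O)c1cnc(N2CCN(C3CCN(Cc4ccc(Cl)cc4)CC3)[C@@H](C)C2)c(Cl)c1` gives 520 nM. Compound 3 `C[C@H]1CN(c2ncc(C(=O)NCC3CCCCC3)cc2Cl)CCN1C1CCN(Cc2ccc(Cl)cc2)CC1` differs from compound 2 in one place: (cyclohexylmethyl)carbamoyl in place of acetamido on an aromatic carbon. Among the compounds with values here, no measured step matches this change. Within the data shown here, the only step known, a 65-fold lower number from compound 1 to compound 2 (1.81 log units; beyond the scatter), shows that the group on this aromatic carbon can move the number a great deal, but it gives no guide to a larger amide. A step of a 6.3-fold higher number from compound 2 to compound 3 (0.80 log units; beyond the scatter) is therefore expected, with wide uncertainty. Compound 3 is estimated at 50 nM, within a range from 6 nM to 400 nM.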

Compound 3, half-maximal inhibitory concentration: 2.4 nM
For compound 3 the middle estimate is 21-fold (1.32 log units) above the measured one; measured number outside the range, below it.
By their numbers in this assay, from the lowest: compound 3; then compound 2; then compound 1.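

In this assay, (cyclohexylmethyl)carbamoyl in place of acetamido gives a 3.3-fold lower number from compound 2 to compound 3 (0.52 log units; beyond the scatter), so this aromatic carbon accepts a much larger group with a six-membered carbon ring, and the number still falls. The amide also works when attached through its carbonyl carbon rather than through its nitrogen. Going by these compounds alone, replacing the methyl on the carbonyl carbon with (cyclohexylmethyl)amino gives a 220-fold lower number from compound 1 to compound 3 (2.34 log units; beyond the scatter), a far larger change than the one from compound 2.

On these data alone, whether an amine, a carboxylic acid or a plain methyl on the amide nitrogen would keep the number this low remains open. Nothing available explains why the larger amide does better.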